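A few compounds are considered here, and "the series" means these few. Any claim that something is new, unique, unknown or untested is made for them only; others in the source may bear on it.

Working notes on the series, read in an ADME assay on microsomes from liver (Homo sapiens) for pharmacokinetics, read by LC-MS, with a stated time of 60 min, tested at 1 uM; a lower number here means slower removal, a higher number faster removal of the compound. Among the compounds with values here, compound 1 (`O=C(NCc1ccc(S(=O)(=O)C2CCC(F)(F)CC2)cc1)N1Cc2ccncc2C1`) gives 6 mL/min/kg, and compound 2 (`O=C(NCc1ccc(S(=O)(=O)C2CCOCC2)cc1)N1Cc2ccncc2C1`) gives 6 mL/min/kg, so compound 2 stands level with compound 1, its only measured neighbour. The next change leads to compound 3 (`CN1CCC(S(=O)(=O)c2ccc(CNC(=O)N3Cc4ccncc4C3)cc2)CC1`): 1-methylpiperidin-4-yl in place of oxan-4-yl on a sulfonyl sulfur. Within the data shown here, it falls on the sulfonyl sulfur, the place of the one measured step, no change at the digits printed from compound 1 to compound 2 (within the scatter), which stays within the scatter. Among the measured compounds shown here, that step is the only guide, and it covers no group with a nitrogen in the ring, so the support is thin. Resting on it, no move beyond the scatter is expected in this assay, with any drift more likely upward. The expected step is a 1.3-fold higher number from compound 2 to compound 3 (0.12 log units; within the scatter). For compound 3 the estimated clearance is 8 mL/min/kg, with an expected range of 5 mL/min/kg to 15 mL/min/kg.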

Compound 3, clearance: 11 mL/min/kg
For compound 3 the middle estimate is 1.4-fold (0.14 log units) below the measured one, within the range that was stated.
By their numbers in this assay, from the lowest: compounds 1, 2 and 3 (each within the scatter of the next).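

On the sulfonyl sulfur, the series now includes a group with a nitrogen in its ring: in this assay, 1-methylpiperidin-4-yl in place of oxan-4-yl gives a 1.8-fold higher number from compound 2 to compound 3 (0.26 log units; within the scatter), and the same group in place of 4,4-difluorocyclohexyl gives a 1.8-fold higher number from compound 1 to compound 3 (0.26 log units; within the scatter). All three groups read so far at this place therefore stay within the scatter of one another, so the exchange of oxygen for a nitrogen bearing a methyl group produces no step beyond it. Nothing measured here accounts for the size of either step.

From the compounds shown here alone, it remains open whether an open-chain group such as ethyl, or a ring bearing a carboxylic acid or a primary amine, would stay within the scatter on the sulfonyl sulfur. Going by these compounds, with only these three values, it is also open whether any group at this place can produce a step beyond the scatter.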